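This account rests on a few compounds, and the source may have more. Where it says the series, first, only, none or still open, it means among the compounds named here.

Measured so far:
- compound 1, `COc1cc(/C=C/C(=O)C2=C(/C=C/c3ccc(O)c(OC)c3)NC(=S)NC2c2ccccc2)ccc1O`; in a functional assay, with a stated time of 20 min, tested at 20 uM (a lower number here means a weaker effect, a higher number a stronger effect of the compound at the concentration tested), compound 1 gives 36.6%.
- compound 2, `COc1cc(/C=C/C(=O)C2=C(/C=C/c3ccc(O)c(OC)c3)NC(=S)NC2c2ccc(N(C)C)cc2)ccc1O`; in this assay compound 2 gives 72.1%.

Compound 2 holds the higher of the two numbers; its nearest comparison is compound 1, and the step of a number 35.5 percentage points higher from compound 1 to compound 2 (beyond the scatter) lies beyond the scatter. Compound 3, `COc1cc(/C=C/C(=O)C2=C(/C=C/c3ccc(O)c(OC)c3)NC(=S)NC2c2ccccc2Cl)ccc1O`, has not yet been measured in this assay. It differs from compound 2 in one place: 2-chlorophenyl in place of 4-(dimethylamino)phenyl on a saturated ring carbon. Within the data shown here, the only measured step that bears on this change is a number 35.5 percentage points higher from compound 1 to compound 2 (beyond the scatter), which shows what the dimethylamino group on the aromatic carbon added when set against hydrogen. Among the measured compounds shown here, compound 3 lacks that group and carries a 2-chlorophenyl instead, for which no measured pair exists, so compound 1 remains the closest reference point. A step downward from compound 2 is expected, of a size comparable to the step already seen, because a number 35.5 percentage points higher from compound 1 to compound 2 (beyond the scatter) was large; the expected step is a number 32.1 percentage points lower from compound 2 to compound 3 (beyond the scatter). Compound 3 is estimated at 40% in this assay, within a range from 25% to 56%.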

Compound 3, a percentage reported as activity, at one concentration (the size of the read-out at that concentration, not a potency): 39.2%
Beside the measured number, compound 3's estimate is 0.8 percentage points above it; the measured number falls inside the stated range.
By their numbers in this assay, from the lowest: compounds 1 and 3 (each within the scatter of the next); then compound 2.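

In this assay, 2-chlorophenyl in place of 4-(dimethylamino)phenyl on the saturated ring carbon gives a number 32.9 percentage points lower from compound 2 to compound 3 (beyond the scatter), so the high reading of compound 2 does not extend to every substituted phenyl at this position. Chloro in place of hydrogen on the aromatic carbon gives a number 2.6 percentage points higher from compound 1 to compound 3 (within the scatter), which leaves 2-chlorophenyl and unsubstituted phenyl indistinguishable here; among these three compounds, only the 4-(dimethylamino)phenyl compound stands apart from the other two. Nothing available explains why the dimethylamino compound separates from the chloro and hydrogen compounds in this way.

The change from compound 2 to compound 3 alters both the substituent and its numbered place on the phenyl, so these compounds cannot separate the contribution of the group from that of its location. Also open, on these data alone, is whether a primary amine, a pyrrolidine or a methoxy group on the phenyl would match compound 2 at 72.1%, or whether that reading is specific to dimethylamino.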